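A few compounds are considered here, and "the series" means these few. Any claim that something is new, unique, unknown or untested is made for them only; others in the source may bear on it.

Measured so far in an assay on isolated protein for inhibition of glutathione S-transferase Mu 2 (Homo sapiens), with a stated time of 10 min; a higher number here means a weaker inhibitor, a lower number a stronger inhibitor:

- compound 1 `O=C(O)CCC(=O)OCCCCCCSc1ccc([N+](=O)[O-])c2nonc12`: 160 nM
- compound 2 `O=C(CCC(=O)OCCCCCCSc1ccc([N+](=O)[O-])c2nonc12)Nc1ccccc1`: 700 nM
- compound 3 `O=C(CCC(=O)OCCCCCCSc1ccc([N+](=O)[O-])c2nonc12)Nc1ccc(F)cc1`: 320 nM

Compound 3 holds the second highest of the three numbers in this assay. Its nearest neighbour is compound 1, and that gap, a 2.0-fold higher number from compound 1 to compound 3 (0.30 log units; within the scatter), stays within the scatter; its furthest is compound 2, and that gap, a 2.2-fold lower number from compound 2 to compound 3 (0.34 log units; beyond the scatter), lies beyond it.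

Compound 4 `COc1ccc(NC(=O)CCC(=O)OCCCCCCSc2ccc([N+](=O)[O-])c3nonc23)cc1` differs from compound 3 in one place: methoxy in place of fluoro on an aromatic carbon. For the measured compounds named here, the only measured step on the same aromatic carbon is a 2.2-fold lower number from compound 2 to compound 3 (0.34 log units; beyond the scatter), a modest move; the two steps that change the carbonyl substituent, a 4.4-fold higher number from compound 1 to compound 2 (0.64 log units; beyond the scatter) and a 2.0-fold higher number from compound 1 to compound 3 (0.30 log units; within the scatter), show that swapping the group on the carbonyl carbon shifts the number only moderately. Going by the values given here, no measured step introduces a methoxy, so its effect on the number is unknown. On this basis, the expected step of a 1.3-fold higher number from compound 3 to compound 4 (0.10 log units; within the scatter) is small, with no clear direction beyond the scatter. Compound 4 is therefore estimated at 400 nM, within a range of 150 nM to 1100 nM.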

Compound 4, half-maximal inhibitory concentration: 130 nM
Compound 4: middle estimate off by 3.1-fold (0.49 log units), on the high side; the whole stated range lies above it.
By their numbers in this assay, from the lowest: compounds 4, 1 and 3 (each within the scatter of the next, the first and the last beyond it); then compound 2.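

In this assay, for the compounds shown here, the group on the aromatic carbon para to a large group turns out to matter more than the earlier compounds could show: methoxy in place of fluoro gives a 2.5-fold lower number from compound 3 to compound 4 (0.39 log units; beyond the scatter), and methoxy in place of hydrogen gives a 5.4-fold lower number from compound 2 to compound 4 (0.73 log units; beyond the scatter). Among these three compounds the number falls from hydrogen through fluoro to methoxy, and the anilide-type amide no longer stands apart from the free acid, with a 1.2-fold lower number from compound 1 to compound 4 (0.09 log units; within the scatter) leaving the two indistinguishable. No measured evidence here explains why methoxy has this effect.

Going by these compounds, whether the same order extends to other groups on this carbon, such as an amine or an ethoxy, remains open. Also open, on these data alone, is how a methoxy would behave on a different carbon of the same ring.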